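The source may report more compounds than this note shows. Statements on the series, on what has been measured and on what is new or still open speak of the compounds shown alone.

Compound 1 `O=C1C=CCC/C1=C\C=C\c1ccc(Cl)cc1` is the weaker of the two compounds measured here. In a functional assay on Bel-7402 cells (Homo sapiens) for cytotoxicity, read by MTT assay, with a stated time of 72 h (a lower number here means a stronger inhibitor, a higher number a weaker inhibitor), compound 1 gives 3200 nM, the highest number of the two. Its nearest neighbour is compound 2 `COc1cc(/C=C/C=C2\CCC=CC2=O)ccc1O`, which in this assay gives 800 nM, a lower number, and the gap between the two lies beyond the usual scatter of the method, so compound 2 is the stronger inhibitor of the pair. Both share the same core, a dienone linked to a benzene ring, and differ only in what sits on that ring.

Compound 3 `CN(C)c1ccc(/C=C/C=C2\CCC=CC2=O)cc1` has not been measured yet. It differs from compound 1 by a single change (dimethylamino in place of chloro on an aromatic carbon). Among the measured compounds shown here, no measured pair in this set shows this exact change, so its effect has to be judged from what compound 2 shows. Compound 3 is expected to move toward a lower number, by a step of a 2.7-fold lower number from compound 1 to compound 3 (0.43 log units; beyond the scatter), a modest but likely real gain. Compound 3 is therefore estimated to give about 1200 nM, within a range from 400 nM to 3600 nM.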

Compound 3, half-maximal inhibitory concentration: 900 nM
Estimate against measurement, compound 3: 1.3-fold (0.12 log units) above; the range from low to high includes it.
By their numbers in this assay, from the lowest: compounds 2 and 3 (each within the scatter of the next); then compound 1.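

Among the compounds shown here, until now, the place that carries the chloro in compound 1 had no clean test, since compound 2 differs from compound 1 in more than one place, so compound 3 provides the first single change at this position. In this assay the move to dimethylamino on this aromatic carbon, para to a large group, brings a 3.6-fold lower number from compound 1 to compound 3 (0.55 log units; beyond the scatter) and so shows that the number responds to the group at this position and that chloro is not required for activity in these cells. Nothing available here explains why the number moves with this change.

From the compounds shown here alone, only these two groups can be compared directly at this position, so it remains open whether a plain amine, diethylamino or a carboxylic acid in the same place would lower the number further or raise it. Going by these compounds, it is also open whether the same exchange would produce a step of similar size if a longer chain joined the aromatic ring to the rest of the shared core.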